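The source may report more compounds than this note shows. Statements on the series, on what has been measured and on what is new or still open speak of the compounds shown alone.

Compound 1 `N#Cc1ccc(NC(=O)c2ccc(Cl)cc2O)cc1` is an amide linking a chloro-substituted, hydroxy-bearing ring to a second ring that carries a cyano group. In a functional assay on HL-60 cells (Homo sapiens) for cytotoxicity, read by luminescence and CellTiter-Glo, with a stated time of 3 days (a higher number here means a weaker inhibitor, a lower number a stronger inhibitor), compound 1 gives 1300 nM, the highest of the three numbers measured here. Compound 2 `O=C(Nc1ccc(C(F)(F)F)cc1)c1ccc(Cl)cc1O`, which carries trifluoromethyl in place of cyano on an aromatic carbon, gives 630 nM, and the step of a 2.1-fold lower number from compound 1 to compound 2 (0.31 log units; beyond the scatter) is a modest one. Compound 3 `O=C(Nc1cc(C(F)(F)F)cc(C(F)(F)F)c1)c1cc(Br)c(F)cc1O` differs from compound 1 in several places at once; compound 3 gives 250 nM, and the two values alone show compound 3 with the lower number.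

Compound 4 `N#Cc1ccc(NC(=O)c2ccc(-c3ccncc3)cc2O)cc1` is the compound still to be measured. It differs from compound 1 by pyridin-4-yl in place of chloro on an aromatic carbon, on an aromatic carbon of a six-membered aromatic ring of carbon only, meta to a hydroxy group and para to a large group. Among the measured compounds shown here, no measured step touches this position: the only single-point step recorded, a 2.1-fold lower number from compound 1 to compound 2 (0.31 log units; beyond the scatter), concerns the other ring and says nothing about what the pyridin-4-yl ring will do. The expected step of a 1.2-fold higher number from compound 1 to compound 4 (0.06 log units; within the scatter) is therefore set near zero, with a wide range to reflect the lack of guidance. For compound 4 the estimate in this assay is 1500 nM, with a range from 400 nM to 6000 nM.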

Compound 4, half-maximal inhibitory concentration: 7090 nM
Compound 4: the middle estimate sits 4.7-fold (0.67 log units) below what was measured, outside the stated range (above it).
By their numbers in this assay, from the lowest: compound 3; then compound 2; then compound 1; then compound 4.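

Among the compounds shown here, until now, nothing showed how this position on the shared core responds to a change, as the only single-place step concerned the other ring. In this assay, placing pyridin-4-yl where chloro stood gives a 5.5-fold higher number from compound 1 to compound 4 (0.74 log units; beyond the scatter), so the group at this position matters, and this replacement of a single chlorine by a six-membered aromatic ring weakens the compound by a step beyond the scatter. No measurement shown here offers a reason for this rise.

The compounds shown cannot separate the presence of an added aromatic ring from the presence of its nitrogen, and a comparison with a plain phenyl ring at this position would be needed to tell the two apart; how a methyl group, a methoxy group or an amine would behave here also remains open. It is equally unknown whether pyridin-4-yl would give a step of similar size on compound 2, which carries trifluoromethyl in place of cyano on the other ring.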